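The source may hold more compounds than are shown below. What is called first, only, known or untested is meant among the compounds shown, and "the series" means these compounds.

In a functional assay on Huh-7 cells (Homo sapiens) for antiproliferative activity, read by CCK-8 assay, with a stated time of 72 h; on this read-out lower numbers stand for stronger inhibition of growth and higher numbers for weaker inhibition of growth:
Compound 1 `CCC1C(=O)N(C)c2cnc(-n3ccc4cc(C(=O)NC(C)C)ccc43)nc2N1c1ccn(C)n1`: 6740 nM
Compound 2 `CCC1C(=O)N(C)c2cnc(-n3ccc4cc(F)ccc43)nc2N1c1ccn(C)n1`: "not active" (no number reported)
Compound 3 `CC[C@@H]1C(=O)N(C)c2cnc(-n3ccc4cc(C(=O)NC(C)C)ccc43)nc2N1C1CCCC1`: 1660 nM

Compound 2 has no place on the numeric scale, since it is reported only as "not active" (no number reported). The unmeasured compound 4 `CCCCNC(=O)c1ccc2c(ccn2-c2ncc3c(n2)N(c2ccn(C)n2)C(CC)C(=O)N3C)c1` is the next to consider. The change butylcarbamoyl in place of fluoro on an aromatic carbon puts butylcarbamoyl in place of fluoro on an aromatic carbon. In this assay the step is expected to run towards stronger inhibition of growth, but its size cannot be stated without a number for compound 2. This expectation rests on compound 1, which also carries a carbamoyl group and gives 6740 nM. A result without a number remains possible. For compound 4 the expected value is 5000 nM, with an estimated range of 1800 nM to 15000 nM.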

Compound 4, concentration for 50% growth inhibition: 8670 nM
Compound 4: the middle estimate sits 1.7-fold (0.24 log units) below what was measured; the measured number falls inside the stated range.
By their numbers in this assay, from the lowest: compound 3; then compounds 1 and 4 (each within the scatter of the next).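

In this assay butyl and isopropyl on the amide-type nitrogen are not told apart: the step is a 1.3-fold higher number from compound 1 to compound 4 (0.11 log units; within the scatter) and stays within the scatter. Compound 4, with butylcarbamoyl in place of fluoro, gives 8670 nM while compound 2 is reported only as not active, so the size of that step cannot be read. No measurement shown explains either result.

Open, as far as these compounds go, is whether a chain longer than butyl, or an amine or a carboxylic acid at the end of the chain, would shift the number beyond the scatter.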